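From carboxy to hydroxymethyl: the step to compound 4

The compounds below may be only part of what the source reports. "The series", "measured", "known", "first", "only" and "open" are said of these compounds alone.

In a functional assay on Z-138 cells (Homo sapiens) for inhibition, read by luminescence and CellTiter-Glo, with a stated time of 72 h (a lower number here means a stronger inhibitor, a higher number a weaker inhibitor), compound 3 (`C/C=C/C(=O)N1CCCC(n2nc(-c3ccc(Oc4ccccc4)cc3)cc2C(=O)O)C1`) gives > 60000 nM, which is a limit of the assay and not a number. Compound 4 (`C/C=C/C(=O)N1CCCC(n2nc(-c3ccc(Oc4ccccc4)cc3)cc2CO)C1`) has hydroxymethyl in place of carboxy on an aromatic carbon. Among the compounds with values here, compound 2 (`C/C=C/C(=O)N1CCCC(n2nc(-c3ccc(Oc4ccccc4)cc3)cc2C(=O)OCC)C1`) gives 19100 nM, and the one measured step at this place is an at least 3.1-fold higher number from compound 2 to compound 3 (0.49 log units; beyond the scatter). Compound 1 (`O=C(CCl)N1CCCC(n2nc(-c3ccc(Oc4ccccc4)cc3)cc2CO)C1`) carries the same hydroxymethyl, with a different amide group, and gives 400 nM. Those two values suggest that the carboxy form lies at the weak end of this assay. The expected change is an at least 10-fold lower number from compound 3 to compound 4 (1.00 log units; beyond the scatter), towards a lower number and beyond the scatter. Compound 4 is estimated at 6000 nM, with an expected range of 1000 nM to 30000 nM.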

Compound 4, half-maximal inhibitory concentration: 51100 nM
For compound 4 the middle estimate is 8.5-fold (0.93 log units) below the measured one; the measured number lies above the stated range.
By their numbers in this assay, from the lowest: compound 1; then compound 2; then compound 4. At a limit, above all of these: compound 3.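

On the prop-1-en-1-yl amide, hydroxymethyl in place of carboxy gives an at least 1.1-fold lower number from compound 3 to compound 4 (0.06 log units; that floor lies within the scatter). Replacing ethoxycarbonyl at this position gives a 2.7-fold higher number from compound 2 to compound 4 (0.43 log units; beyond the scatter). With hydroxymethyl held fixed, the amide group matters more, as prop-1-en-1-yl in place of chloromethyl gives a 130-fold higher number from compound 1 to compound 4 (2.11 log units; beyond the scatter) on the same core. Compound 3 stands at a limit of the assay and not at a number, so the full size of the step from carboxy to hydroxymethyl cannot be read: the limit of > 60000 nM in this assay, at which 1 of the 4 values shown sits.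

From the compounds shown here alone, whether the chloromethyl amide would respond to ethoxycarbonyl or carboxy at this position stays open. So does the effect of an aminomethyl group or a longer hydroxyalkyl chain on this aromatic carbon.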